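A Second Ester Group and Survival of the Compound

The compounds below may be only part of what the source reports. "The series", "measured", "known", "first", "only" and "open" are said of these compounds alone.

This study asks how much of each compound is left after standing in rat blood plasma. In an ADME assay on a cell-free system (plasma, Rattus norvegicus) for metabolic stability, read by LC-MS, with a stated time of 60 min, at 37 degrees C, tested at 50 uM (on this read-out higher numbers stand for a more stable compound and lower numbers for a less stable compound), compound 1 `Cc1oc(=O)oc1COC(=O)c1cccc(NC(=O)[C@@H]2C[C@H](SC3=C(C(=O)O)N4C(=O)[C@H]([C@@H](C)O)[C@H]4[C@H]3C)CN2)c1` gives 0%. Compound 3 `C[C@@H](O)[C@H]1C(=O)N2C(C(=O)OCOC(=O)OC3CCCCC3)=C(S[C@@H]3CN[C@H](C(=O)Nc4cccc(C(=O)O)c4)C3)[C@H](C)[C@H]12` gives 0% in this assay, level with compound 1 at the digits reported and within the usual scatter. For compound 2 `CC(C)OC(=O)c1cccc(NC(=O)[C@@H]2C[C@H](SC3=C(C(=O)O)N4C(=O)[C@H]([C@@H](C)O)[C@H]4[C@H]3C)CN2)c1` this assay gives "not determined" (no result reported), so no number is available for it. Compound 4 `Cc1oc(=O)oc1COC(=O)C1=C(S[C@@H]2CN[C@H](C(=O)Nc3cccc(C(=O)OCc4oc(=O)oc4C)c3)C2)[C@H](C)[C@@H]2[C@@H]([C@@H](C)O)C(=O)N12` has not yet been measured. It differs from compound 1 in one place: a group of 8 heavy atoms (5 carbon, 3 oxygen; one five-membered aromatic ring with 2 hetero atoms) in place of a hydrogen atom, on an oxygen next to a carbonyl group. Among the measured compounds shown here, no measured pair shows this change, so the expectation rests on compound 1 alone, which in this assay already gives 0%, leaving no room for a lower reading. The step of no change at the digits printed from compound 1 to compound 4 (within the scatter) is therefore expected to be none beyond the scatter. Compound 4 is estimated at 0%, with a range from 0% to 10%.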

Compound 4, percent of the compound remaining: 0%
Estimate against measurement, compound 4: no gap at the digits printed, and the stated range covers the measured number.
By their numbers in this assay, from the lowest: compounds 1, 3 and 4 (each within the scatter of the next).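

In this assay, among the compounds shown here, the first step between two measured compounds is no change at the digits printed from compound 1 to compound 4 (within the scatter), and it comes from a group of 8 heavy atoms in place of a hydrogen atom, on an oxygen next to a carbonyl group. For the compounds shown here, the earlier compounds held no such pair, and this one shows only that the reading stays at the bottom of the scale with the group present. With both compounds at that floor, the pair cannot show whether the added group changes how much compound survives, and no measured finding here bears on the result.

Still open, from the compounds shown here alone, is how this oxygen behaves with a group that leaves some compound to measure. An ethyl ester or an amide at this place, for example, might give a reading above the floor, and only such a reading would allow a real comparison.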